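One ring swapped on a sulfonamide nitrogen

A few compounds are considered here, and "the series" means these few. Any claim that something is new, unique, unknown or untested is made for them only; others in the source may bear on it.

For the measured compounds named here, in a functional assay on DU-145 cells (Homo sapiens) for antiproliferative activity, read by MTT assay, with a stated time of 72 h (a higher number here means a weaker inhibitor, a lower number a stronger inhibitor), compound 3 `COc1cccc(N(C)S(=O)(=O)C2CC3OC2C(c2ccc(NC(=O)CCCCCCC(=O)O)cc2)=C3c2ccc(O)cc2)c1` gives 62200 nM, the only true number in this small series. Compound 1 `CN(c1ccccc1)S(=O)(=O)C1CC2OC1C(c1ccc(NC(=O)CCCCCCC(=O)O)cc1)=C2c1ccc(O)cc1` reaches only a limit of the assay, > 100000 nM. Compound 2 `Cc1ccc(N(C)S(=O)(=O)C2CC3OC2C(c2ccc(NC(=O)CCCCCCC(=O)O)cc2)=C3c2ccc(O)cc2)cc1` also reaches only a limit, > 100000 nM. Every measured step therefore touches (the limit of > 100000 nM in this assay, at which 2 of the 3 values shown sit).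

The next compound, compound 4 `CN(c1ccccc1Cl)S(=O)(=O)C1CC2OC1C(c1ccc(NC(=O)CCCCCCC(=O)O)cc1)=C2c1ccc(O)cc1`, carries 2-chlorophenyl in place of 3-methoxyphenyl on a sulfonamide nitrogen. The bearing steps are those that change this same ring. One is an at least 1.6-fold lower number from compound 1 to compound 3 (0.20 log units; that floor lies within the scatter), and another is an at least 1.6-fold lower number from compound 2 to compound 3 (0.20 log units; that floor lies within the scatter). On these data alone, these are floors, so the true sizes remain unknown. The third is a step that the two limits leave unreadable from compound 1 to compound 2.

So far, compound 3 is the only compound with a methoxy group and the only one to give a number in this assay. Compound 4 has no methoxy group, which points towards a weaker result, but three compounds make thin evidence and none of them has a chlorine. A modest move towards a higher number is therefore expected, with no step beyond the scatter. The estimated change is a 1.4-fold higher number from compound 3 to compound 4 (0.14 log units; within the scatter). Compound 4 is estimated at 85000 nM, with an expected range from 40000 nM to 150000 nM.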

Compound 4, half-maximal inhibitory concentration: 73500 nM
The estimate for compound 4 lay 1.2-fold (0.06 log units) above the measured number; low and high end bracket the measured number.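

For the compounds shown here, compound 4 carries chlorine and no methoxy group, yet it still gives a true number in this assay, so a methoxy group is no longer the only ring change here that does so. Putting 2-chlorophenyl in place of 3-methoxyphenyl on the sulfonamide nitrogen gives a 1.2-fold higher number from compound 3 to compound 4 (0.07 log units; within the scatter), so this assay does not separate these two rings. The other two new steps, an at least 1.3-fold lower number from compound 2 to compound 4 (0.13 log units; that floor lies within the scatter) and an at least 1.3-fold lower number from compound 1 to compound 4 (0.13 log units; that floor lies within the scatter), give only floors, because their true sizes are cut off by an assay limit: (the limit of > 100000 nM in this assay, at which 2 of the 4 values shown sit).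

On these data alone, the step between compound 1 and compound 2 cannot be read, so it stays open whether the methyl group on the ring of compound 2 changes anything in this assay. Also open, as far as these compounds go, is whether a nitrile or an amine on this ring would give a number clearly apart from those of compound 3 and compound 4, which differ both in the group they carry and in where it sits on the ring.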